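Chain extension on the benzylamine arm of the triazine series

This account rests on a few compounds, and the source may have more. Where it says the series, first, only, none or still open, it means among the compounds named here.

Compound 1 `Nc1nc(NCc2ccccc2)nc(-c2c(F)cccc2CO)n1` gives 3.69 in a functional assay on cells for positive allosteric modulation of G-protein coupled receptor 68 (Homo sapiens), read by a luciferase reporter and cAMP accumulation, with a stated time of 30 min, at pH 6.8 and pH 8.3, in the presence of a further agent that is not named here; on this read-out lower numbers stand for lower potency and higher numbers for higher potency (the scale is a negative logarithm). Compound 2 `Nc1nc(NCc2ccccc2F)nc(-c2c(F)cccc2CO)n1` gives 4.22, and compound 3 `COc1ccccc1CNc1nc(N)nc(-c2c(F)cccc2CO)n1` gives 4.11. Compound 3 thus stands second highest of the three: a number 0.11 log units lower from compound 2 to compound 3 (within the scatter) is within the scatter, whereas a number 0.42 log units higher from compound 1 to compound 3 (beyond the scatter) and a number 0.53 log units higher from compound 1 to compound 2 (beyond the scatter) both lie beyond it. Compound 4 `Nc1nc(NCCCCc2ccccc2)nc(-c2c(F)cccc2CO)n1` carries 3-phenylpropyl in place of 2-methoxyphenyl on a saturated chain carbon bound to a nitrogen on an aromatic ring. Within the data shown here, none of the measured steps covers a chain of this kind; the only bearing is that compound 1, whose phenyl carries neither fluoro nor methoxy, sits lowest. A fall of about a number 0.41 log units lower from compound 3 to compound 4 (beyond the scatter) in this assay is therefore expected, with wide uncertainty. Compound 4 is estimated at 3.7, with a range from 3.2 to 4.3.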

Compound 4, negative logarithm of the antagonist equilibrium constant: 4.04
The estimate for compound 4 lay 0.34 log units below the measured number; low and high end bracket the measured number.
By their numbers in this assay, from the lowest: compound 1; then compounds 4, 3 and 2 (each within the scatter of the next).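

Longer-chain notes: at this position, on a saturated chain carbon bound to a nitrogen on an aromatic ring, an unsubstituted phenyl group need not stay at the length in compound 1, since a number 0.35 log units higher from compound 1 to compound 4 (beyond the scatter). Neither a number 0.07 log units lower from compound 3 to compound 4 (within the scatter) nor a number 0.18 log units lower from compound 2 to compound 4 (within the scatter) separates the 3-phenylpropyl group from the 2-methoxyphenyl and 2-fluorophenyl groups, so chain extension and ring substitution read alike here. No evidence on the origin of these steps accompanies the series. Still open, going by these compounds, is how a longer chain, or an amine at the end of the chain, would read.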